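Swapping the leaving group on the ketone-bearing chain

The source may report more compounds than this note shows. Statements on the series, on what has been measured and on what is new or still open speak of the compounds shown alone.

Compound 1 `CC(C)[C@H](NC(=O)COc1cccc2ccccc12)C(=O)N[C@@H](CC(=O)O)C(=O)COc1cc(C(F)(F)F)n(C)n1`: 46000 nM
Compound 2 `CC(C)[C@H](NC(=O)COc1cccc2ccccc12)C(=O)N[C@@H](CC(=O)O)C(=O)CSc1nccc(C(F)(F)F)n1`: > 200000 nM

In a functional assay on Jurkat cells (Homo sapiens) for inhibition (a lower number here means a stronger inhibitor, a higher number a weaker inhibitor), compound 2 gives only a limit of the assay, > 200000 nM; the value of compound 1 is a number, 46000 nM. Compound 3 `CC(C)[C@H](NC(=O)COc1cccc2ccccc12)C(=O)N[C@@H](CC(=O)O)C(=O)COn1nnc2ccccc2c1=O` carries a group of 12 heavy atoms (7 carbon, 3 nitrogen, 2 oxygen; one six-membered aromatic ring of carbon only, one six-membered aromatic ring with 3 hetero atoms) in place of a group of 11 heavy atoms (5 carbon, 2 nitrogen, 3 fluorine, 1 sulfur; one six-membered aromatic ring with 2 hetero atoms), on a saturated chain carbon bound to a carbonyl carbon. Going by the values given here, the only measured step at this position, an at least 4.3-fold higher number from compound 1 to compound 2 (0.63 log units; beyond the scatter), changed an oxygen-linked group for a sulfur-linked one and weakened inhibition. Compound 3 returns to an oxygen link, so a return toward the level of compound 1 is expected, as an at least 3.3-fold lower number from compound 2 to compound 3 (0.52 log units; beyond the scatter). Compound 3 is estimated at 60000 nM, between 10000 nM and 200000 nM.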

Compound 3, half-maximal inhibitory concentration: 137000 nM
Compound 3: middle estimate off by 2.3-fold (0.36 log units), on the low side; measured number inside the range.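

Keeping an oxygen link does not by itself preserve inhibition in this assay: the step is a 3.0-fold higher number from compound 1 to compound 3 (0.47 log units; beyond the scatter), so the group attached to that oxygen also matters. Against the sulfur-linked group, the change is an at least 1.4-fold lower number from compound 2 to compound 3 (0.16 log units; that floor lies within the scatter). Compound 2 stands at a limit of the assay, so its true distance from compound 3 remains unknown: the limit of > 200000 nM in this assay, at which 1 of the 3 values shown sits.

The compounds shown never place the same aromatic group on both an oxygen and a sulfur link, so the effects of link and group cannot be separated. On these data alone, how a plain phenoxy group would compare at this position also remains open.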